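Trimming the amide end of compound 2

The source may report more compounds than this note shows. Statements on the series, on what has been measured and on what is new or still open speak of the compounds shown alone.

Compound 2 `COc1cc(-c2nn(-c3cccc(NC(=O)Nc4cccc(C(F)(F)F)c4)c3)cc2-c2ccncc2)ccc1Cl` in a functional assay on BT-549 cells (Homo sapiens) for inhibition, read by sulforhodamine B assay, with a stated time of 48 h (a lower number here means a stronger inhibitor of growth, a higher number a weaker inhibitor of growth), gives 3810 nM, a number that lies within the scatter of compound 1 `COc1cc(-c2nn(-c3cccc(NC(=O)Nc4cc(C(F)(F)F)cc(C(F)(F)F)c4)c3)cc2-c2ccncc2)ccc1Cl`, which in this assay gives 3060 nM. Among the measured compounds shown here, only one measured step exists, a 1.2-fold higher number from compound 1 to compound 2 (0.10 log units; within the scatter), and it stays within the scatter. Compound 3 `COc1cc(-c2nn(-c3cccc(NC(=O)c4ccccc4)c3)cc2-c2ccncc2)ccc1Cl` differs from compound 2 by a larger change: phenyl in place of (3-(trifluoromethyl)phenyl)amino on a carbonyl carbon. For the measured compounds named here, no measured step removes this amino link, so the single known step offers only weak guidance. The expected step is a 1.6-fold higher number from compound 2 to compound 3 (0.20 log units; within the scatter), toward a weaker inhibitor of growth. Compound 3 is therefore estimated at 6000 nM, with a range from 2500 nM to 15000 nM.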

Compound 3, concentration for total growth inhibition: > 100000 nM
Compound 3 was reported as a limit; the forecaster's own chance of this, stated with the estimate: 15%; middle value at least 16-fold (1.22 log units) from the limit.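

Compound 3 carries a limit of the assay, not a number: the limit of > 100000 nM in this assay, at which 1 of the 3 values shown sits. Putting phenyl in place of (3-(trifluoromethyl)phenyl)amino on the carbonyl carbon gives an at least 26-fold higher number from compound 2 to compound 3 (1.41 log units; beyond the scatter), whereas losing one trifluoromethyl gave a 1.2-fold higher number from compound 1 to compound 2 (0.10 log units; within the scatter), so the result in this assay depends far more on what sits on this carbonyl carbon. This single change removes both the amino link, with its hydrogen-bond donor, and the trifluoromethyl group.

Which of these two losses matters remains open, and a plain phenylamino group on this carbonyl carbon would separate them. Whether a simple alkylamine there would keep growth inhibition is also unsettled.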